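Cytotoxicity notes: acetylphenyl extension of the ethyl ester

This account rests on a few compounds, and the source may have more. Where it says the series, first, only, none or still open, it means among the compounds named here.

Compound 3 `CCOC(=O)CCCCCOc1cccc(CN(C(=O)c2ccccc2)C(C)C)c1` is the ethyl ester of the hexanoic acid chain on the shared core. In an ADME assay on HepG2 cells (Homo sapiens) for cytotoxicity, read by CellTiter-Glo and resazurin assay, with a stated time of 72 h (a lower number here means that less compound is needed, a higher number that more compound is needed for the effect), compound 3 gives > 26000 nM, which is a limit of the assay and not a number. Compound 1 `CC(C)N(Cc1cccc(OCCCCCC(=O)O)c1)C(=O)c1ccccc1` is the parent free acid. In this assay compound 1 gives > 26000 nM, again a limit. Compound 2 `CC(C)COc1cccc(-c2ccc(C(=O)N(Cc3cccc(OCCCCCC(=O)O)c3)C(C)C)cc2)c1` carries a 3-(isobutoxy)phenyl in place of hydrogen on an aromatic carbon of compound 1. In this assay compound 2 gives > 26000 nM, also a limit. The two measured steps, a step that the two limits leave unreadable from compound 1 to compound 2 and a step that the two limits leave unreadable from compound 1 to compound 3, cannot be sized because the limit of > 26000 nM in this assay, at which 3 of the 3 values shown sit, covers every value obtained so far.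

Compound 4 `CCOC(=O)CCCCCOc1cccc(CN(C(=O)c2ccc(-c3cccc(C(C)=O)c3)cc2)C(C)C)c1` is not yet measured. It differs from compound 3 by 3-acetylphenyl in place of hydrogen on an aromatic carbon. For the measured compounds named here, this change is of the same kind as the aryl addition that gave compound 2, where no readable shift appeared, and no measured step offers a direction. With all three values at the limit, the expected step is a step that the limit leaves unreadable from compound 3 to compound 4, none beyond the scatter. Compound 4 is estimated at 30000 nM, in the range 10000 nM to 100000 nM, and a further limit rather than a number is expected to be reported.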

Compound 4, half-maximal effective concentration: > 26000 nM
Compound 4 gave a limit, no number (the forecaster's own chance of this, stated with the estimate: 75%); the middle value does not contradict the limit.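

No step can be read from compound 3 to compound 4, and both compounds give only a limit of the assay in this assay: the limit of > 26000 nM in this assay, at which 4 of the 4 values shown sit. The compounds shown leave open whether the free acid, the ethyl ester or either aryl addition on the shared core differs at all in this assay.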